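The source may report more compounds than this note shows. Statements on the series, on what has been measured and on what is new or still open speak of the compounds shown alone.

Values measured so far in a functional assay on PC-3 cells (Homo sapiens) for cytotoxicity, read by MTT assay (a higher number here means a weaker inhibitor, a lower number a stronger inhibitor), are:

- compound 1 `COc1cccc(CSc2nnc([C@@H](C)c3ccc4cc(OC)ccc4c3)n2-c2ccc(Cl)cc2)c1` gives 138000 nM
- compound 2 `COc1ccc2cc([C@H](C)c3nnc(SCc4c(Cl)cccc4Cl)n3-c3cccc(Cl)c3)ccc2c1` gives 165000 nM

Compound 1 and compound 2 lie within the scatter of each other, so the two values give compound 1 no distinct rank and together mark a single level of weak inhibition. Among the compounds with values here, the two compounds differ in more than one place, and no pair of measured compounds differs in one place only. Within the data shown here, the series therefore offers no measured step to serve as a guide.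

Compound 3 `COc1ccc2cc([C@H](C)c3nnc(SCc4ccc(C)cc4)n3-c3ccc(Cl)cc3)ccc2c1` has yet to be measured in this assay. Its change from compound 1 is 4-methylphenyl in place of 3-methoxyphenyl on a saturated chain carbon bound to a sulfur, with 4-methylphenyl in place of 3-methoxyphenyl on a saturated chain carbon bound to a sulfur.

With nothing measured on this change, the expectation rests on compound 1 at 138000 nM and compound 2 at 165000 nM. No step beyond the scatter is expected, and no direction is favoured. The expected step is a 1.1-fold lower number from compound 1 to compound 3 (0.03 log units; within the scatter). For compound 3 the estimated value is 130000 nM, with an expected range of 50000 nM to 280000 nM.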

Compound 3, half-maximal inhibitory concentration: 8400 nM
Estimate against measurement, compound 3: 15-fold (1.19 log units) above; measured number outside the range, below it.
By their numbers in this assay, from the lowest: compound 3; then compounds 1 and 2 (each within the scatter of the next).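

Replacing 3-methoxyphenyl with 4-methylphenyl on a saturated chain carbon bound to a sulfur gives a 16-fold lower number from compound 1 to compound 3 (1.22 log units; beyond the scatter) in this assay. Within the data shown here, this large step is the first measured, and it shows that the group at this position can shift the number well beyond the scatter, whereas the two earlier values gave no such sign. Two features change together here, methoxy becoming methyl and the substituent moving from ring position 3 to 4, and no information at hand accounts for the shift or assigns it to either feature.

The compounds shown leave open which of these two features carries the step, a question that 4-methoxybenzyl and 3-methylbenzyl on the sulfur would address directly. Also open, from the compounds shown here alone, is how far this position tolerates other groups, such as an aminobenzyl, a carboxybenzyl or a longer chain like 2-phenylethyl, and whether the step holds when the rest of the molecule differs from the core of compound 1.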